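Replacing a propyl chain with (trifluoromethyl)sulfanyl

The compounds below may be only part of what the source reports. "The series", "measured", "known", "first", "only" and "open" are said of these compounds alone.

In a functional assay on the whole organism with Rattus norvegicus as the target (on this read-out higher numbers stand for an effect only at larger amounts of compound and lower numbers for an effect already at smaller amounts), compound 1 `CCCc1ccc2nc(N)sc2c1` gives 6 mg/kg. Compound 2 `CCCCCCc1ccc2nc(N)sc2c1` gives 7 mg/kg, which lies within the scatter of the value for compound 1, so the two stand level. Compound 3 `CCCCCCCc1ccc2nc(N)sc2c1` returns only a limit, > 10 mg/kg.

Compound 4 `Nc1nc2ccc(SC(F)(F)F)cc2s1` keeps the shared core but changes the group on it: (trifluoromethyl)sulfanyl in place of propyl on an aromatic carbon. In words, (trifluoromethyl)sulfanyl takes the place of propyl on an aromatic carbon.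

The measured steps only lengthen the chain. They are a 1.2-fold higher number from compound 1 to compound 2 (0.07 log units; within the scatter), an at least 1.6-fold higher number from compound 1 to compound 3 (0.22 log units; that floor lies within the scatter) and an at least 1.4-fold higher number from compound 2 to compound 3 (0.15 log units; that floor lies within the scatter). All three are small, but none of them replaces the chain with the new group, so they offer only loose guidance. On that basis, no shift beyond the scatter is expected in this assay. The expected change is a 1.5-fold lower number from compound 1 to compound 4 (0.18 log units; within the scatter). For compound 4 the estimated value is 4 mg/kg, with an expected range from 1.5 mg/kg to 10 mg/kg.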

Compound 4, dose for half-maximal effect: 8 mg/kg
For compound 4 the middle estimate is 2.0-fold (0.30 log units) below the measured one; low and high end bracket the measured number.
By their numbers in this assay, from the lowest: compounds 1, 2 and 4 (each within the scatter of the next). At a limit, above all of these: compound 3.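

In this assay, putting (trifluoromethyl)sulfanyl in place of propyl on this aromatic carbon gives a 1.3-fold higher number from compound 1 to compound 4 (0.12 log units; within the scatter), so the two compounds stand level. The earlier compounds shown here varied only the length of a carbon chain, whereas this change brings in sulfur and fluorine atoms and a hydrogen-bond acceptor, and the position still accepts it without a shift beyond the scatter. Compound 3 remains a limit and not a number: the limit of > 10 mg/kg in this assay, at which 1 of the 4 values shown sits.

From the compounds shown here alone, whether this position would accept a group of a different kind, such as an amine or a carboxylic acid, stays open. A whole-animal read-out like this one also cannot say why the chain and the sulfur-linked group stand level.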